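A few compounds are considered here, and "the series" means these few. Any claim that something is new, unique, unknown or untested is made for them only; others in the source may bear on it.

Of the compounds shown here, two have been measured in an ADME assay on the whole organism (Mus musculus, strain C57BL6/N) for pharmacokinetics, read by LC-MS, with a stated time of 24 h, at a dose of 50 mg/kg by the oral route; a higher number here means more compound in the circulation at the dose given, a lower number less compound in the circulation. Compound 1 `NC(=O)c1cnc2c(c1Cl)CCN2` gives 28200 nM, and compound 2 `C[C@@H]1Cc2cc(C(N)=O)cnc2N1` gives 127000 nM. Compound 2 therefore holds the higher of the two numbers, and its gap to compound 1 lies beyond the usual scatter. These two compounds are not related by a change in one place, so their gap cannot be assigned to any single group.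

Compound 3 `NC(=O)c1cnc2c(c1)CCN2` has not yet been measured. It differs from compound 2 by hydrogen in place of methyl on a saturated ring carbon. Among the measured compounds shown here, no measured step shows what this change does in this assay, so the expectation rests on the two values alone. Compound 3 is expected to lie most likely within the span from compound 1 at 28200 nM to compound 2 at 127000 nM. The expected move is a modest fall that stays within the scatter, estimated as a 1.6-fold lower number from compound 2 to compound 3 (0.20 log units; within the scatter). For compound 3 the estimated maximal plasma concentration is 80000 nM, with an expected range of 30000 nM to 180000 nM.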

Compound 3, maximal plasma concentration: 176000 nM
Beside the measured number, compound 3's estimate is 2.2-fold (0.34 log units) below it, within the range that was stated.
By their numbers in this assay, from the lowest: compound 1; then compounds 2 and 3 (each within the scatter of the next).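

In this assay, hydrogen in place of methyl on a saturated ring carbon, next to the ring nitrogen, gives a 1.4-fold higher number from compound 2 to compound 3 (0.14 log units; within the scatter), so at this place the methyl can go without a change that stands clear of repeat measurements. Hydrogen in place of chloro on an aromatic carbon gives a 6.2-fold higher number from compound 1 to compound 3 (0.80 log units; beyond the scatter), which makes this aromatic carbon the one place among those shown where a single change separates two compounds beyond the scatter. Nothing measured alongside these numbers bears on why either step comes out as it does.

Going by these compounds, each change is seen only once, so it stays open whether the step at the aromatic carbon is specific to chloro or would also appear with fluoro, methoxy or an amine at that carbon. On these data alone, it also stays open whether an ethyl or a hydroxymethyl on the saturated ring carbon would remain as close to compound 3 as the methyl of compound 2 does.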